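Swapping Ethyl for Methoxy on the Benzyl Ring

The source may report more compounds than this note shows. Statements on the series, on what has been measured and on what is new or still open speak of the compounds shown alone.

Compound 3, `CCc1ccc(Cn2c(CCc3ccccc3)nnc2[C@H](NC(=O)c2ccncc2)c2c[nH]c3ccccc23)cc1`, gives in an in vitro assay on LLC-PK1 cells for displacement of a labelled ligand from growth hormone secretagogue receptor type 1 (Homo sapiens) (a higher number here means a weaker inhibitor, a lower number a stronger inhibitor), only a limit, > 1000 nM. For the measured compounds named here, it is the one compound among the three measured that sits at the limit of > 1000 nM in this assay, at which 1 of the 3 values shown sits. Two measured relatives frame it. Compound 2, `COc1ccc(Cn2c(CCc3ccccc3)nnc2[C@H](NC(=O)c2ccncc2)c2c[nH]c3ccccc23)c(OC)c1`, carries a 2,4-dimethoxyphenyl where compound 3 has a 4-ethylphenyl, and compound 2 gives 58 nM in this assay. Compound 1, `COc1ccc(Cn2c(CCc3ccccc3)nnc2[C@H](NC(=O)c2ccccn2)c2c[nH]c3ccccc23)cc1`, shares the 4-methoxyphenyl of the unmeasured compound but differs from it in another part, and compound 1 gives 0.7 nM in this assay. Going by the values given here, the only step that can be read directly is an at least 17-fold higher number from compound 2 to compound 3 (1.23 log units; beyond the scatter), a large loss when the methoxy-bearing ring gives way to the ethyl-bearing one.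

Compound 4, `COc1ccc(Cn2c(CCc3ccccc3)nnc2[C@H](NC(=O)c2ccncc2)c2c[nH]c3ccccc23)cc1`, has not yet been measured. It differs from compound 3 in one place: methoxy in place of ethyl on an aromatic carbon. This undoes part of the change seen between compound 2 and compound 3, putting a methoxy back where compound 3 has ethyl, though compound 4 keeps a single methoxy where compound 2 has two. Because an at least 17-fold higher number from compound 2 to compound 3 (1.23 log units; beyond the scatter) was large, the step in the reverse direction is also expected to be large, toward a lower number. The expected step is an at least 25-fold lower number from compound 3 to compound 4 (1.39 log units; beyond the scatter). For compound 4 the estimated value in this assay is 40 nM, with a range from 10 nM to 200 nM.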

Compound 4, half-maximal inhibitory concentration: 220 nM
Compound 4: middle estimate off by 5.5-fold (0.74 log units), on the low side; the whole stated range lies below it.
By their numbers in this assay, from the lowest: compound 1; then compound 2; then compound 4. At a limit, above all of these: compound 3.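

Put on the aromatic carbon para to a large group, methoxy gives a lower number than ethyl in this assay, with an at least 4.5-fold lower number from compound 3 to compound 4 (0.65 log units; beyond the scatter), so the single swap of ethyl for methoxy accounts for part of the loss seen earlier. The rest of that loss now has a place of its own: with a 3.8-fold higher number from compound 2 to compound 4 (0.58 log units; beyond the scatter), the 2,4-dimethoxyphenyl of compound 2 and the 4-methoxyphenyl of compound 4 are shown to differ beyond the scatter, so the extra methoxy counts too. The other end of the molecule matters far more, since moving the pyridine attachment gives a 310-fold higher number from compound 1 to compound 4 (2.50 log units; beyond the scatter), the largest of these steps, with pyridin-2-yl in place of pyridin-4-yl on the carbonyl carbon as the better of the two.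

As far as these compounds go, the true size of the ethyl-to-methoxy step stays open because compound 3 stands at a limit: the limit of > 1000 nM in this assay, at which 1 of the 4 values shown sits. Whether a hydroxyl, a chlorine or a propyl chain on that same aromatic carbon would fall nearer to methoxy or to ethyl is open, as is whether the gain from pyridin-2-yl would hold with the 2,4-dimethoxyphenyl of compound 2 in place.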